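The compounds below may be only part of what the source reports. "The series", "measured", "known", "first", "only" and "open" are said of these compounds alone.

The series is built on a shared core, and within it compound 1 `C/C(=N\NC(=O)COc1cccc2ccccc12)c1ccc(C#N)cc1Br` is tested in an ADME assay on MT4 cells (Homo sapiens) for cytotoxicity, read by MTT assay, with a stated time of 4 days; a lower number here means that less compound is tolerated, a higher number that more compound is tolerated. In this assay, within the data shown here, compound 1 gives 12.1 ug/mL, which is the lowest of the two numbers so far. Among the measured compounds shown here, the only neighbour is compound 2 `O=C(COc1cccc2ccccc12)N/N=C/c1cccc(O)c1`, which in this assay gives 32.6 ug/mL; the gap from compound 1 to compound 2 is beyond the scatter, so compound 2 is tolerated at a higher concentration than compound 1.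

The step under study leads from compound 1 to compound 3 `C/C(=N\NC(=O)COc1cccc2ccccc12)c1ccccc1O`, which has not yet been measured in this assay. The change is 2-hydroxyphenyl in place of 2-bromo-4-cyanophenyl on a carbon with a double bond to nitrogen. For the measured compounds named here, no pair of measured compounds differs in this one place, so the size of the step is not known from the data. Compound 2, which also carries a hydroxyphenyl group, is tolerated at a higher level than compound 1, so a rise is expected rather than a fall, of modest size and likely beyond the scatter. For compound 3 the expected value in this assay is 25 ug/mL, with a range from 10 ug/mL to 60 ug/mL. The expected step is a 2.1-fold higher number from compound 1 to compound 3 (0.32 log units; beyond the scatter).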

Compound 3, half-maximal cytotoxic concentration: 11.3 ug/mL
The estimate for compound 3 lay 2.2-fold (0.34 log units) above the measured number; the range from low to high includes it.
By their numbers in this assay, from the lowest: compounds 3 and 1 (each within the scatter of the next); then compound 2.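

In this assay, among these compounds, the exchange of 2-bromo-4-cyanophenyl for 2-hydroxyphenyl on a carbon with a double bond to nitrogen gives a 1.1-fold lower number from compound 1 to compound 3 (0.03 log units; within the scatter), the first measured step at this position. The exchange is not a small one: a bromine and a nitrile leave, and a hydroxyl group with its hydrogen-bond donor enters, yet the two numbers stay within the scatter of each other, so for this pair the readout does not tell the two groups apart. No other measurement bears on why this is so.

The compounds shown leave open what each part of the exchange does alone, since the bromine, the nitrile and the hydroxyl group all differ in this single step, and a phenyl carrying only the bromine or only the nitrile would separate them. They also leave open whether this one result extends to other groups at the same place, such as a phenyl ring carrying an amine or a carboxylic acid instead of the hydroxyl group.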